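This account rests on a few compounds, and the source may have more. Where it says the series, first, only, none or still open, it means among the compounds named here.

Working notes on the benzylsulfanyl series in a functional assay on the whole organism (artery, strain albino) with Rattus norvegicus as the target, with a stated time of 360 min, at a dose of 10 mg/kg by the oral route; on this read-out higher numbers stand for more inhibition at the one dose given (going by the name of the read-out) and lower numbers for less inhibition. Three compounds carry numbers. Compound 1 `COc1ccc(C2N=C(SCc3ccc(Cl)cc3)NC(C)=C2C(=O)Nc2ccc(F)cc2)cc1OC` gives 37.1%. Compound 2 `CC1=C(C(=O)Nc2ccc(Br)cc2)C(c2ccc(Cl)cc2Cl)N=C(SCc2ccccc2Cl)N1` gives 38.1%. Compound 3 `COc1ccc(C2N=C(SCc3ccccc3Cl)NC(C)=C2C(=O)Nc2ccc(Br)cc2)cc1` gives 20.6%, the lowest of the three; compound 1 stands nearest, above it beyond the scatter, and compound 2 stands furthest, also beyond the scatter. Within the data shown here, the one step between measured compounds that differ in a single place, a number 17.5 percentage points lower from compound 2 to compound 3 (beyond the scatter), concerns the 4-methoxyphenyl in place of 2,4-dichlorophenyl on a saturated ring carbon.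

Compound 4 `COc1ccc(C2N=C(SCc3ccc(F)cc3)NC(C)=C2C(=O)Nc2ccc(Br)cc2)cc1` is not yet measured. It differs from compound 3 only in 4-fluorophenyl in place of 2-chlorophenyl on a saturated chain carbon bound to a sulfur. Among the measured compounds shown here, no measured step touches this place: the one known step lies on the saturated ring carbon, not on the saturated chain carbon bound to a sulfur. Compound 1 also carries a 4-chlorobenzyl group rather than a 2-chlorobenzyl group, but it differs from compound 3 in further places as well, so its values and those of compound 3 can only be set side by side, not read as a step. The direction of the change is therefore undecided; a step no larger than modest is expected, with the estimate leaning slightly upward toward the level of compound 1, as a number 7.4 percentage points higher from compound 3 to compound 4 (within the scatter). Compound 4 is expected to give 28%, within 12% to 45%.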

Compound 4, a percentage reported as inhibition, in the whole organism at one dose (the size of the read-out at that dose, not a potency): 33.5%
Compound 4: the middle estimate sits 5.5 percentage points below what was measured, and the stated range covers the measured number.
By their numbers in this assay, from the lowest: compound 3; then compounds 4, 1 and 2 (each within the scatter of the next).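

Among these compounds, this is the first measured step at the saturated chain carbon bound to a sulfur, and it shows that the group held there matters in this assay: replacing 2-chlorophenyl with 4-fluorophenyl gives a number 12.9 percentage points higher from compound 3 to compound 4 (beyond the scatter). With compound 3 as the reference, the read-out therefore responds to changes at two separate places, since the saturated ring carbon already gave a number 17.5 percentage points lower from compound 2 to compound 3 (beyond the scatter). The new step changes the halogen and its numbered place on the phenyl ring together, so it cannot assign the gain to either one, and no measurement at hand bears on the cause of the change.

Still open, as far as these compounds go, is how this position would read with a plain benzyl, 2-fluorobenzyl or 4-chlorobenzyl group on the otherwise unchanged frame of compound 4, or with a longer chain such as 2-phenylethyl in place of the benzyl group. Also open, from the compounds shown here alone, is whether the gain from 4-fluorobenzyl carries over when 2,4-dichlorophenyl, as in compound 2, sits on the saturated ring carbon.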